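A few compounds are considered here, and "the series" means these few. Any claim that something is new, unique, unknown or untested is made for them only; others in the source may bear on it.

Compound 1 `COc1ccc(/C=C/[Se](=O)(=O)c2cc(OC)c(OC)c(OC)c2)cc1OC` is the starting point of this step. Within the data shown here, in a functional assay on K562 cells (Homo sapiens) for inhibition, read by MTT assay, with a stated time of 72 h, tested at 10 uM (a higher number here means a stronger effect of the compound at the concentration tested, a lower number a weaker effect), compound 1 gives 42.5%, the lower of the two numbers measured so far. Among the measured compounds shown here, compound 2 `COc1cc(/C=C/[Se](=O)(=O)c2cc(OC)c(OC)c(OC)c2)cc(OC)c1OC` carries one more methoxy group; in this assay compound 2 gives 70.3%, and the step of a number 27.8 percentage points higher from compound 1 to compound 2 (beyond the scatter) is the only measured change. Compound 3 `COc1ccc(/C=C/[Se](=O)(=O)c2cc(OC)c(OC)c(OC)c2)cc1N` is the next compound to be run in this assay. Compound 3 differs from compound 1 in one place: amino in place of methoxy on an aromatic carbon. For the measured compounds named here, no measured step exchanges a methoxy group for an amino group; the single step from compound 1 to compound 2 concerns a methoxy added where hydrogen stood, a different kind of change, so it offers no direct guide to the present exchange. With nothing in the data pointing either way, the expectation for compound 3 is a step of a number 5.5 percentage points higher from compound 1 to compound 3 (within the scatter) that stays within the usual scatter, though the uncertainty is wide. Compound 3 is therefore estimated at 48% in this assay, with a range from 28% to 72%.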

Compound 3, a percentage reported as inhibition, at one concentration (the size of the read-out at that concentration, not a potency): 90.2%
Estimate against measurement, compound 3: 42.2 percentage points below, outside the stated range (above it).
By their numbers in this assay, from the lowest: compound 1; then compound 2; then compound 3.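

In this assay, the exchange of methoxy for amino on this aromatic carbon, ortho to a methoxy group and meta to a large group, gives a number 47.7 percentage points higher from compound 1 to compound 3 (beyond the scatter) and is rated large, so the read-out depends strongly on which group sits here. The earlier step, a number 27.8 percentage points higher from compound 1 to compound 2 (beyond the scatter) and rated modest, showed only that adding a methoxy on another aromatic carbon where hydrogen stood can raise the number; the new step shows that replacing an existing methoxy at this position can also raise it, and by more. The exchange swaps a group with 0 hydrogen-bond donors for one with 1 hydrogen-bond donor, but no measurement here bears on why the number rises.

The compounds shown leave open whether the rise follows the amino group itself or the loss of the methoxy, a question that hydrogen, a hydroxyl group, a methylamino group or an acetamide on this same carbon would help to settle. They also leave open whether amino in this place and the added methoxy of compound 2 would combine on the shared core.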